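The source may report more compounds than this note shows. Statements on the series, on what has been measured and on what is new or still open speak of the compounds shown alone.

In an in vitro ADME assay on microsomes from liver (Homo sapiens) for metabolic stability, using NADPH (on this read-out lower numbers stand for slow clearance and higher numbers for fast clearance), compound 1 (`COc1ccc(OC(F)(F)F)cc1Cn1c(C(=O)NCC(C)(C)CO)cc2cc(C#N)ccc21`) gives 69 mL.min-1.g-1 and compound 2 (`COc1ccc(Cl)cc1Cn1c(C(=O)NCC(C)(C)CO)cc2cc(C#N)ccc21`) gives 83 mL.min-1.g-1 on the same scale. Among the measured compounds shown here, the two stand level, with a 1.2-fold higher number from compound 1 to compound 2 (0.08 log units; within the scatter) as the only measured step. For the measured compounds named here, that step sits on an aromatic carbon, so no measured step covers the change to compound 3 (`COc1ccc(Cl)cc1Cn1c(C(=O)NCC2(CO)CCC2)cc2cc(C#N)ccc21`), which is 1-(hydroxymethyl)cyclobutyl in place of 1-(hydroxymethyl)-1-methylethyl on a saturated chain carbon bound to an amide-type nitrogen and nothing else. With nothing measured at this place, the expected change is a 1.1-fold higher number from compound 2 to compound 3 (0.04 log units; within the scatter) and no more than the scatter. For compound 3 the estimated value is 90 mL.min-1.g-1 with an expected range from 50 mL.min-1.g-1 to 155 mL.min-1.g-1 in this read-out.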

Compound 3, intrinsic clearance in microsomes: 196 mL.min-1.g-1
For compound 3 the middle estimate is 2.2-fold (0.34 log units) below the measured one; the measured number lies above the stated range.
By their numbers in this assay, from the lowest: compounds 1 and 2 (each within the scatter of the next); then compound 3.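

In this assay, 1-(hydroxymethyl)cyclobutyl in place of 1-(hydroxymethyl)-1-methylethyl gives a 2.4-fold higher number from compound 2 to compound 3 (0.37 log units; beyond the scatter) on a saturated chain carbon bound to an amide-type nitrogen. Among the compounds shown here, this is the first step beyond the scatter, so clearance does respond to a change at this place. Nothing at hand explains the rise. For the compounds shown here, whether it follows from the ring itself or from the added carbon stays open with only this one pair. A 1-(hydroxymethyl)cyclopropyl group, or an amine in place of the hydroxyl, would probe this position further.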